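Swapping Ethyl for Methyl on a Mirror-Image Core

This account rests on a few compounds, and the source may have more. Where it says the series, first, only, none or still open, it means among the compounds named here.

Of the compounds shown here, three have been measured in an ADME assay on cells for inhibition of cytochrome P450 11B1, mitochondrial (Homo sapiens), read by HTRF; on this read-out higher numbers stand for weaker inhibition and lower numbers for stronger inhibition. Compound 1 `CCC(=O)N[C@@H]1CCCc2c1cncc2N1C(=O)c2ccc(Cl)cc2[C@@H]1C` gives 414 nM, compound 2 `CCC(=O)N[C@@H]1CCCc2c1cncc2N1C(=O)c2ccc(Cl)cc2[C@@H]1CC` gives 345 nM, and compound 3 `CCC(=O)N[C@@H]1CCCc2c1cncc2N1C(=O)c2ccc(Cl)cc2[C@H]1CC` gives 10200 nM. Compound 2 and compound 3 share every atom and bond and differ only in how one centre is drawn: the two compounds have the same atoms and bonds and differ only in configuration as drawn: 1 of 2 stereo elements differ; a stereocentre at a saturated ring carbon is drawn S in compound 2 and R in compound 3. That small difference on paper goes with a large difference in this assay, a 30-fold higher number from compound 2 to compound 3 (1.47 log units; beyond the scatter), a step that rests solely on (the fact that compounds 2 and 3 differ only in the configuration as drawn).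

Compound 4 `CCC(=O)N[C@@H]1CCCc2c1cncc2N1C(=O)c2ccc(Cl)cc2[C@H]1C` has not yet been measured. It stands to compound 3 as compound 1 stands to compound 2: hydrogen in place of methyl on a saturated chain carbon bound to a saturated ring carbon, the same change as hydrogen in place of methyl on a saturated chain carbon bound to a saturated ring carbon, made at the same place. Where that change has been seen once before, it barely moved the number: a 1.2-fold higher number from compound 2 to compound 1 (0.08 log units; within the scatter). On that basis the step is expected to be small again, a 1.1-fold lower number from compound 3 to compound 4 (0.05 log units; within the scatter), with compound 4 keeping the weaker inhibition seen for the core of compound 3. Compound 4 is therefore estimated at 9000 nM, with a likely range from 3500 nM to 25000 nM.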

Compound 4, half-maximal inhibitory concentration: 9410 nM
Beside the measured number, compound 4's estimate is 1.0-fold (0.02 log units) below it; the range from low to high includes it.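

In this assay, shortening ethyl to methyl by putting hydrogen in place of methyl gives a 1.1-fold lower number from compound 3 to compound 4 (0.04 log units; within the scatter), so the change stays as small on this core as it was on the other: the same change on two cores in this assay, a 1.2-fold higher number (0.08 log units; within the scatter) from compound 2 to compound 1 and a 1.1-fold lower number (0.04 log units; within the scatter) from compound 3 to compound 4, 1.3-fold (0.11 log units) apart, within the scatter of two such steps

The configuration at the ring carbon matters far more in this methyl pair, with a 23-fold higher number from compound 1 to compound 4 (1.36 log units; beyond the scatter), and that gap goes with the drawn configuration alone: the fact that compounds 1 and 4 differ only in the configuration as drawn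

This shows one small change carrying over between two cores that differ at one stereocentre, in one assay; it does not show that the change would stay this small on a core altered anywhere else, and it gives no reason for the effect of configuration.

The compounds shown leave open whether a longer chain, such as propyl, or a hydroxymethyl group at this carbon would also leave the number unchanged on both cores. They also leave open whether the large gap between the configurations would persist with an amine in place of the chloro group.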